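Trading a methoxy for a methyl on the pendant ring

This account rests on a few compounds, and the source may have more. Where it says the series, first, only, none or still open, it means among the compounds named here.

Compound 1 `CCOC(=O)c1c(-c2ccc(OC)cc2)[nH]c2cccc(OC)c2c1=O` carries a 4-methoxyphenyl group on the shared core. In a physicochemical assay for solubility, in phosphate buffer, at pH 7.4 (on this read-out lower numbers stand for lower solubility and higher numbers for higher solubility), compound 1 gives > 100000 nM, which is a limit of the assay and not a number. Two further compounds with the same core have been measured. Compound 2 `CCOC(=O)c1c(-c2cccc(C(F)(F)F)c2)[nH]c2cc(OC)ccc2c1=O` gives 19000 nM in this assay. Compound 3 `CCOC(=O)c1c(-c2ccccc2C)[nH]c2cc(OC)ccc2c1=O` gives > 100000 nM in this assay, and this too is a limit rather than a number. Compound 1 therefore stands at the limit of > 100000 nM in this assay, at which 2 of the 3 values shown sit, so it cannot be ordered against compound 3, while compound 2 lies well below that limit.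

Compound 4 `CCOC(=O)c1c(-c2cccc(C)c2)[nH]c2cccc(OC)c2c1=O` has not yet been measured. It differs from compound 1 by 3-methylphenyl in place of 4-methoxyphenyl on an aromatic carbon. Among the measured compounds shown here, no two measured compounds differ in only one place, so no measured step speaks directly to this change, and the limit for compound 1 leaves only a downward step open to view. The account expects a modest fall for compound 4, an at least 1.6-fold lower number from compound 1 to compound 4 (0.22 log units; that floor lies within the scatter), with a fair chance that the assay again returns only a limit. Compound 4 is expected to give 60000 nM in this assay, with a range from 20000 nM to 150000 nM.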

Compound 4, solubility: > 100000 nM
Compound 4: only a limit was reported; the forecaster's own chance of this, stated with the estimate: 40%; at least 1.6-fold (0.22 log units) between middle value and limit.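

In this assay compound 4 returns a limit and not a number: the limit of > 100000 nM in this assay, at which 3 of the 4 values shown sit.

Among the compounds shown here, compound 1 also stands at a limit, so no step from compound 1 to compound 4 can be read. The compounds shown leave open whether 3-methylphenyl in place of 4-methoxyphenyl moves the read-out at all, and in which direction.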